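The compounds below may be only part of what the source reports. "The series", "measured", "known", "first", "only" and "open" are said of these compounds alone.

The series is studied in a functional assay on HT-29 cells (Homo sapiens) for cytotoxicity, read by MTT assay, with a stated time of 72 h; on this read-out higher numbers stand for weaker inhibition of growth and lower numbers for stronger inhibition of growth. Compound 3 `O=C(/N=C(/NC(=O)c1cnc2ccccc2c1)[Se]Cc1ccccc1)c1cnc2ccccc2c1` gives 26100 nM in this assay, and compound 2 `C[Se]/C(=N\C(=O)c1cnc2ccccc2c1)NC(=O)c1cnc2ccccc2c1` gives 200 nM. The change from compound 3 to compound 2, (hydrogen in place of phenyl on a saturated chain carbon bound to a selenium atom), produced a 130-fold lower number from compound 3 to compound 2 (2.12 log units; beyond the scatter). Compound 1 `O=C(/N=C(/NC(=O)c1csc([N+](=O)[O-])c1)[Se]Cc1ccccc1)c1csc([N+](=O)[O-])c1` gives 9250 nM in this assay; how its core differs from the core of compound 3 is not broken down here. Compound 4 `C[Se]/C(=N\C(=O)c1csc([N+](=O)[O-])c1)NC(=O)c1csc([N+](=O)[O-])c1` is related to compound 1 by the same change, (hydrogen in place of phenyl on a saturated chain carbon bound to a selenium atom), at the same place. Among the compounds with values here, it is expected that compound 4 shows a 93-fold lower number from compound 1 to compound 4 (1.97 log units; beyond the scatter), a step resting on the single earlier case, a 130-fold lower number from compound 3 to compound 2 (2.12 log units; beyond the scatter), though the cores differ and only one example supports the transfer. The estimate for compound 4 in this assay is therefore 100 nM, within a range from 25 nM to 700 nM.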

Compound 4, concentration for 50% growth inhibition: 0.63 nM
Compound 4: the middle estimate sits 160-fold (2.20 log units) above what was measured; measured number outside the range, below it.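

In this assay the change from benzyl to methyl gave a 15000-fold lower number from compound 1 to compound 4 (4.17 log units; beyond the scatter), so the direction held on both cores while the size did not: the same change on two cores in this assay, a 130-fold lower number (2.12 log units; beyond the scatter) from compound 3 to compound 2 and a 15000-fold lower number (4.17 log units; beyond the scatter) from compound 1 to compound 4, 110-fold (2.05 log units) apart, beyond the scatter of two such steps

This shows that the direction of the change carried over between these two cores, but that a size read on one core did not serve as a number for the other. Two cores do not show why the steps differ, nor how the change would behave on any further core.

The compounds shown leave open whether an ethyl group or a longer chain in place of benzyl would give numbers closer to those of the methyl or the benzyl compounds on each core. They also leave open how a chain ending in an amine or a carboxylic acid would behave there.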